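Halogen swap at the benzyl arm, cytotoxicity outlook

The compounds below may be only part of what the source reports. "The series", "measured", "known", "first", "only" and "open" are said of these compounds alone.

Compound 3 `Cn1c(SCc2ccc(Br)cc2)nnc1-c1cc([N+](=O)[O-])cc([N+](=O)[O-])c1` stands, in an ADME assay on HepG2 cells (Homo sapiens) for cytotoxicity, with a stated time of 48 h (on this read-out lower numbers stand for stronger inhibition and higher numbers for weaker inhibition), at a limit: compound 3 gives > 30000 nM, a limit of the assay rather than a number. Compound 1 `O=[N+]([O-])c1cc(CSc2nnc(-c3ccccc3)n2Cc2ccccc2)cc([N+](=O)[O-])c1` also reaches only a limit in this assay, > 30000 nM. Compound 2 `COc1ccc(CSc2nnc(-c3cc([N+](=O)[O-])cc([N+](=O)[O-])c3)n2C)cc1` likewise gives only a limit, > 30000 nM. Among the measured compounds shown here, the one measured step, a step that the two limits leave unreadable from compound 2 to compound 3, runs between two limits and its size cannot be read. Every value shown sits at the limit of > 30000 nM in this assay, at which 3 of the 3 values shown sit.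

Compound 4 `Cn1c(SCc2ccc(Cl)c(Cl)c2)nnc1-c1cc([N+](=O)[O-])cc([N+](=O)[O-])c1` differs from compound 3 by 3,4-dichlorophenyl in place of 4-bromophenyl on a saturated chain carbon bound to a sulfur. For the measured compounds named here, the only step that bears on this change, a step that the two limits leave unreadable from compound 2 to compound 3, is unreadable, so neither a size nor a direction can be taken from it; the expectation for compound 4 in this assay is therefore that the limit is reached once more. Compound 4 is estimated at 30000 nM, with a range from 20000 nM to 100000 nM. The implied step a number no higher from compound 3 to compound 4 (the limit leaves the size open) is expected to be none beyond the scatter.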

Compound 4, half-maximal inhibitory concentration: > 30000 nM
Compound 4 gave a limit, no number (the forecaster's own chance of this, stated with the estimate: 85%); the middle value sits exactly at the limit.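

Compound 4, like compound 2 and compound 3, reaches only a limit in this assay, so the steps among these compounds cannot be read: the limit of > 30000 nM in this assay, at which 4 of the 4 values shown sit.

The compounds shown leave open whether any group on the benzyl arm gives a readable number in this assay.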